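This account rests on a few compounds, and the source may have more. Where it says the series, first, only, none or still open, it means among the compounds named here.

In a functional assay on MDA-MB-231 cells (Homo sapiens) for inhibition, read by sulforhodamine B assay (on this read-out higher numbers stand for weaker inhibition of growth and lower numbers for stronger inhibition of growth), compound 2 `Cc1ccc(CCCN2CC=C(CCC(=O)NO)C2=O)cc1` gives 2210 nM, level with compound 1 `CC(C)(C)c1ccc(CCCN2CC=C(CCC(=O)NO)C2=O)cc1`, which in the same assay gives 2210 nM; the step of no change at the digits printed from compound 1 to compound 2 (within the scatter) stays within the scatter. Compound 3 `CC(C)c1ccc(CCCN2CC=C(CCC(=O)NO)C2=O)cc1` differs from compound 2 by isopropyl in place of methyl on an aromatic carbon. Among the measured compounds shown here, the only step that bears on this change is the one from tert-butyl to methyl, which moved nothing, so for compound 3 the expected step in this assay is no change at the digits printed from compound 2 to compound 3 (within the scatter), none beyond the scatter. Compound 3 is therefore estimated at 2210 nM, with a range from 1100 nM to 4400 nM.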

Compound 3, concentration for 50% growth inhibition: 2210 nM
The estimate for compound 3 equals the measured number at the digits printed; the range from low to high includes it.
By their numbers in this assay, from the lowest: compounds 1, 2 and 3 (each within the scatter of the next).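

In this assay the step to isopropyl reads no change at the digits printed from compound 2 to compound 3 (within the scatter), and the step from the other side reads no change at the digits printed from compound 1 to compound 3 (within the scatter). Isopropyl thus fills in the middle of the alkyl groups on this aromatic carbon, para to a large group, and methyl, isopropyl and tert-butyl all stand level, where the earlier compounds offered only the two ends. Nothing at hand accounts for this flat result. As far as these compounds go, whether hydrogen, an amine or a carboxylic acid on this carbon would stay at the same level remains open.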